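Swapping a methylphenyl group on a shared core

The compounds below may be only part of what the source reports. "The series", "measured", "known", "first", "only" and "open" are said of these compounds alone.

Compound 1 `Cc1ccccc1Nc1nc(C)c(C(=O)/C=C/c2ccc(Cl)cc2)s1` and compound 2 `Cc1ccc(Nc2nc(C)c(C(=O)/C=C/c3ccc(Cl)cc3)s2)cc1` share one core and differ only in the group attached to a nitrogen. In a functional assay on BGC-823 cells (Homo sapiens) for cytotoxicity, read by MTT assay (a lower number here means a stronger inhibitor, a higher number a weaker inhibitor), compound 1 gives > 25000 nM, which is a limit of the assay rather than a number. Compound 2 gives > 25000 nM in this assay, again a limit. The change between them is 2-methylphenyl in place of 4-methylphenyl on a nitrogen on an aromatic ring, and the step that the two limits leave unreadable from compound 2 to compound 1 has no readable size because the limit of > 25000 nM in this assay, at which 3 of the 3 values shown sit, holds both of them.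

Compound 3 `COc1cc(/C=C/C(=O)c2sc(Nc3ccc(C)cc3)nc2C)cc(OC)c1OC` carries a different core; how its core differs from the core of compound 2 is not broken down here. In this assay compound 3 gives > 25000 nM, also a limit.

Compound 4 `COc1cc(/C=C/C(=O)c2sc(Nc3ccccc3C)nc2C)cc(OC)c1OC` has not yet been measured. It differs from compound 3 by 2-methylphenyl in place of 4-methylphenyl on a nitrogen on an aromatic ring, the same change as from compound 2 to compound 1, at a place described in the same words. The step from compound 3 to compound 4 in this assay is expected to be a step that the limit leaves unreadable from compound 3 to compound 4, an expectation resting on the value of compound 3 at > 25000 nM and on the earlier pair offering no readable size. Compound 4 is therefore expected to come out near 40000 nM, between 15000 nM and 150000 nM, most likely reported again only as a limit.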

Compound 4, half-maximal inhibitory concentration: 5400 nM
For compound 4 the middle estimate is 7.4-fold (0.87 log units) above the measured one; measured number outside the range, below it.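

On the core of compound 3, placing 2-methylphenyl instead of 4-methylphenyl on the nitrogen gives an at least 4.6-fold lower number from compound 3 to compound 4 (0.66 log units; beyond the scatter) in this assay, so this swap of the methyl position on the ring changes the result on this core, and the printed size is only a minimum. This is a single readable pair, so it shows the effect of the change on one core only, not a rule for the series. It also does not show that the change carries over from one core to another, because the matching step between compound 2 and compound 1 cannot be read, leaving nothing to compare it with: the limit of > 25000 nM in this assay, at which 3 of the 4 values shown sit.

The compounds shown leave open whether the methyl group itself matters on the core of compound 3, since no ethyl group, chlorine or plain unsubstituted phenyl stands in its place here. They also leave open whether the 2-methylphenyl group would give a readable number on any core other than that of compound 3, and how large that number would be.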